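Swapping the anilide ring on compound 2: 4-chlorophenyl to 3-methoxyphenyl

The source may hold more compounds than are shown below. What is called first, only, known or untested is meant among the compounds shown, and "the series" means these compounds.

Compound 1 `COc1cc2nc(Nc3ccc(C#N)cc3)nc(Nc3c(C)cc(/C=C/C#N)cc3C)c2cc1OC` and compound 2 `COc1cc2nc([S+]([O-])CC(=O)Nc3ccc(Cl)cc3)nc(Nc3c(Cl)cc(/C=C/C#N)cc3Cl)c2cc1OC` share a core and were tested in an ADME assay on MT4 cells (Homo sapiens) for cytotoxicity, read by MTT assay, with a stated time of 5 days; on this read-out lower numbers stand for higher toxicity in this test and higher numbers for lower toxicity in this test. In this assay compound 1 gives 10200 nM, while compound 2 gives 14400 nM; the two numbers lie within the usual scatter of each other, so neither can be called more or less toxic than the other. Compound 3 `COc1cccc(NC(=O)C[S+]([O-])c2nc(Nc3c(Cl)cc(/C=C/C#N)cc3Cl)c3cc(OC)c(OC)cc3n2)c1` has not yet been measured. It differs from compound 2 in one place: 3-methoxyphenyl in place of 4-chlorophenyl on an amide-type nitrogen. For the measured compounds named here, no measured pair shows what such a swap does in this assay, and the two numbers known so far stay close together. The expected change from compound 2 to compound 3 is therefore none beyond the scatter, an estimated step of a 1.0-fold lower number from compound 2 to compound 3 (0.01 log units; within the scatter). Compound 3 is expected to give an estimated 14000 nM in this assay, within a range from 7000 nM to 28000 nM.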

Compound 3, half-maximal cytotoxic concentration: >= 167000 nM
Compound 3: no number, only a limit; the forecaster's own chance of this, stated with the estimate: 10%; at least 11-fold (1.07 log units) between middle value and limit.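

The group on the amide-type nitrogen matters in this assay: 3-methoxyphenyl in place of 4-chlorophenyl gives an at least 11-fold higher number from compound 2 to compound 3 (1.06 log units; beyond the scatter), a large move towards lower toxicity in this test. The earlier compounds shown here could not show this, since compound 1 and compound 2 differ in more than one place and no single change had been read at this position. Compound 3 has no number, only a limit of the assay: the limit of >= 167000 nM in this assay, at which 1 of the 3 values shown sits.

This one swap changes the ring's substituent and its place together, so the compounds shown cannot tell which of the two accounts for the step. A 3-chlorophenyl or 4-methoxyphenyl group would separate them, and an unsubstituted phenyl ring would show what the ring does without either the chlorine or the methoxy group.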